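The compounds below may be only part of what the source reports. "The series", "measured", "known", "first", "only" and "open" are said of these compounds alone.

Among the compounds with values here, compound 2 `O=C(COc1ccc(/C=C2\SC(=O)NC2=O)cc1)Nc1ccc(Br)cc1` holds the only definite number here: in a functional assay on KB cells (Homo sapiens) for inhibition (on this read-out higher numbers stand for weaker inhibition of growth and lower numbers for stronger inhibition of growth), compound 2 gives 32100 nM. In this assay compound 1 `O=C(COc1ccc(/C=C2\SC(=O)NC2=O)cc1)Nc1ccc([N+](=O)[O-])cc1` gives > 100000 nM, which is a limit of the assay rather than a number. Within the data shown here, the single measured step, an at least 3.1-fold lower number from compound 1 to compound 2 (0.49 log units; beyond the scatter), thus runs from a limit to a number. Compound 3 `O=C(COc1ccc(/C=C2\SC(=O)NC2=O)cc1)Nc1c(F)cc(Br)cc1F` differs from compound 2 by 4-bromo-2,6-difluorophenyl in place of 4-bromophenyl on an amide-type nitrogen. Among the measured compounds shown here, no measured step touches fluorine; the only step, an at least 3.1-fold lower number from compound 1 to compound 2 (0.49 log units; beyond the scatter), concerned the bromine, which compound 3 keeps, so no change beyond the scatter is expected. Compound 3 is expected to give about 30000 nM in this assay, between 10000 nM and 100000 nM. That estimate implies a 1.1-fold lower number from compound 2 to compound 3 (0.03 log units; within the scatter), expected to stay within the scatter.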

Compound 3, concentration for 50% growth inhibition: > 100000 nM
Compound 3: a limit, no number; the forecaster's own chance of this, stated with the estimate: 25%; middle value at least 3.3-fold (0.52 log units) from the limit.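

In this assay, the group on the amide-type nitrogen proves sensitive to more than the bromine: with the bromine kept, 4-bromo-2,6-difluorophenyl in place of 4-bromophenyl gives an at least 3.1-fold higher number from compound 2 to compound 3 (0.49 log units; beyond the scatter), a weakening of growth inhibition. The step from compound 1 to compound 3 cannot be read, and how far either compound lies past its limit stays unknown: the limit of > 100000 nM in this assay, at which 2 of the 3 values shown sit.

As far as these compounds go, it remains open whether chlorine or methyl in place of the fluorines would keep the number of compound 2. Also open, from the compounds shown here alone, is what an amine or a carboxylic acid in place of the bromine would do.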